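A few compounds are considered here, and "the series" means these few. Any claim that something is new, unique, unknown or untested is made for them only; others in the source may bear on it.

In a functional assay on MCF7 cells (Homo sapiens) for inhibition, read by sulforhodamine B assay, with a stated time of 48 h, tested at 50 uM (a lower number here means less inhibition of growth, a higher number more inhibition of growth at the concentration tested), compound 1 `COc1ccc([C@@H]2C/C(=N/OCc3cn(-c4ccccc4CO)nn3)c3cc(CC=C(C)C)c(OC)cc3O2)cc1` gives 100%, compound 2 `COc1ccc([C@@H]2C/C(=N/OCc3cn(-c4cccc(CO)c4)nn3)c3cc(CC=C(C)C)c(OC)cc3O2)cc1` gives 42%, and compound 3 `COc1ccc([C@@H]2C/C(=N/OCc3cn(-c4ccc(O)cc4)nn3)c3cc(CC=C(C)C)c(OC)cc3O2)cc1` gives 63%. That is the second highest of the three numbers: a number 21 percentage points higher from compound 2 to compound 3 (beyond the scatter), while a number 37 percentage points lower from compound 1 to compound 3 (beyond the scatter). Compound 4 `COc1ccc([C@@H]2C/C(=N/OCc3cn(-c4ccc(C#N)cc4)nn3)c3cc(CC=C(C)C)c(OC)cc3O2)cc1` differs from compound 3 by cyano in place of hydroxy on an aromatic carbon. For the measured compounds named here, no measured step swaps a hydroxy for a cyano, so none bears on this change directly; the steps of a number 58 percentage points lower from compound 1 to compound 2 (beyond the scatter) and a number 37 percentage points lower from compound 1 to compound 3 (beyond the scatter) show only that altering the group on the aromatic nitrogen can move the number a great deal. For compound 4 no step beyond the scatter is expected, a number 8 percentage points lower from compound 3 to compound 4 (within the scatter), though the uncertainty is wide. The estimate for compound 4 is 55%, between 30% and 85%.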

Compound 4, percent growth inhibition at one concentration: 40%
Compound 4: the middle estimate sits 15 percentage points above what was measured, within the range that was stated.
By their numbers in this assay, from the lowest: compounds 4 and 2 (each within the scatter of the next); then compound 3; then compound 1.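

Replacing hydroxy with cyano on this aromatic carbon is not a neutral swap: it gives a number 23 percentage points lower from compound 3 to compound 4 (beyond the scatter). The 4-cyanophenyl group gives a result close to that of the 3-(hydroxymethyl)phenyl group, a number 2 percentage points lower from compound 2 to compound 4 (within the scatter), while the 2-(hydroxymethyl)phenyl group remains well ahead, a number 60 percentage points lower from compound 1 to compound 4 (beyond the scatter). No measurement available here explains these differences.

On these data alone, it remains open whether the change in growth inhibition follows the loss of the hydrogen-bond donor or the arrival of the cyano itself. An amine or a methoxy group on the same carbon would help separate these two readings.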